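A few compounds are considered here, and "the series" means these few. Any claim that something is new, unique, unknown or untested is made for them only; others in the source may bear on it.

Compound 1, `CCC(CC)(c1nnc[nH]1)c1ccc(-c2ccc3cc(F)cc(F)c3c2)[nH]c1=O` — in an assay on CHO cells for displacement of a labelled ligand from prostaglandin E2 receptor EP3 subtype (Homo sapiens), read by radioligand binding (on this read-out lower numbers stand for stronger inhibition and higher numbers for weaker inhibition), compound 1 gives 89 nM.
Compound 2, `CC(C)C(c1ccc(-c2ccc3cccc(F)c3c2)[nH]c1=O)N1CCCCS1(=O)=O` — in this assay compound 2 gives 14 nM.

Among the compounds with values here, compound 2 stands at the lower of the two numbers so far; compound 1 sits at a higher number, and the gap between them lies beyond the scatter. Since these two compounds differ in more than one place, that gap is not assigned to any single change.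

Compound 3 `CC(C)C(Cc1ncc[nH]1)c1ccc(-c2ccc3cccc(F)c3c2)[nH]c1=O` has not yet been measured. It differs from compound 2 in one place: a group of 6 heavy atoms (4 carbon, 2 nitrogen; one five-membered aromatic ring with 2 hetero atoms) in place of a group of 8 heavy atoms (4 carbon, 1 nitrogen, 2 oxygen, 1 sulfur; one six-membered non-aromatic ring with 2 hetero atoms), on a saturated chain carbon bound to an aromatic carbon and a saturated chain carbon. Everything else in the structure is kept. Within the data shown here, no measured pair shows a step of this kind, so the size of the change can only be expected from its own extent: one ring exchanged for a different one on the same chain carbon. On that basis a moderate weakening is expected in this assay, though a number within the scatter of compound 2 would not be surprising. The estimate for compound 3 is 40 nM, with a range from 10 nM to 200 nM, which amounts to an expected step of a 2.9-fold higher number from compound 2 to compound 3 (0.46 log units; beyond the scatter).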

Compound 3, inhibition constant: 11 nM
Estimate against measurement, compound 3: 3.6-fold (0.56 log units) above; measured number inside the range.
By their numbers in this assay, from the lowest: compounds 3 and 2 (each within the scatter of the next); then compound 1.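

At the saturated chain carbon bound to an aromatic carbon and a saturated chain carbon, putting (1H-imidazol-2-yl)methyl in place of the six-membered non-aromatic ring with 2 hetero atoms gives a 1.3-fold lower number from compound 2 to compound 3 (0.10 log units; within the scatter) in this assay, and this step lies within the scatter. The position thus accommodates two quite different groups without a readable difference in the measured number: one is a non-aromatic sulfur-containing ring with 2 hydrogen-bond acceptors and no donor, the other a five-membered aromatic ring with 1 donor and 1 acceptor, so neither the ring type nor these counts separate compound 2 and compound 3 here. Nothing available explains why the two groups read alike.

From the compounds shown here alone, it remains open whether this tolerance extends to other groups on the same carbon, such as an amine, a carboxylic acid or a longer chain, or whether the ring of the (1H-imidazol-2-yl)methyl group matters more than the chain carbon linking it. Compound 1 differs from both other compounds in more than one place, so no single change can be read from it.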